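Thiophene to thiazole swap on the amide benzylic-type arm

The source may report more compounds than this note shows. Statements on the series, on what has been measured and on what is new or still open speak of the compounds shown alone.

In an assay on HEK293 cells for agonist activity at transient receptor potential cation channel subfamily M member 8 (Homo sapiens), read by fluorescence and calcium flux, with a stated time of 15 min (a lower number here means that less compound is needed, a higher number that more compound is needed for the effect), compound 2 `CCN(Cc1ccsc1)C(=O)COc1ccc(C)cc1` gives 88 nM, the lowest of the three numbers seen. Compound 1 `CCN(Cc1cccs1)C(=O)COc1ccc(OC)cc1` gives 120 nM in this assay, within the scatter of compound 2, so no order between the two is read. Compound 3 `CCN(Cc1cccs1)C(=O)c1cc2cc(C)ccc2s1` gives 1600 nM in this assay, a gap beyond the scatter from compound 2. Compound 4 `CCN(Cc1cncs1)C(=O)COc1ccc(C)cc1` is not yet measured in this assay; it differs from compound 2 by 1,3-thiazol-5-yl in place of thiophen-3-yl on a saturated chain carbon bound to an amide-type nitrogen. Within the data shown here, no measured step of this kind is available. A small step toward a higher number is expected, a 1.7-fold higher number from compound 2 to compound 4 (0.23 log units; within the scatter), but not clearly beyond the scatter. Compound 4 is estimated at 150 nM in this assay, within 50 nM to 500 nM.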

Compound 4, half-maximal effective concentration: 1100 nM
Compound 4: the middle estimate sits 7.3-fold (0.87 log units) below what was measured; the measured number lies above the stated range.
By their numbers in this assay, from the lowest: compounds 2 and 1 (each within the scatter of the next); then compounds 4 and 3 (each within the scatter of the next).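

In this assay, 1,3-thiazol-5-yl in place of thiophen-3-yl on a saturated chain carbon bound to an amide-type nitrogen gives a 13-fold higher number from compound 2 to compound 4 (1.10 log units; beyond the scatter) and is a large step. This position therefore tells apart two five-membered aromatic rings with the same heavy-atom count, which differ by one ring nitrogen and one hydrogen-bond acceptor. No measurement on hand accounts for the size of this step.

The compounds shown leave open whether the ring nitrogen alone sets this step or its place in the ring matters. A phenyl, pyridin-3-yl or 1,3-thiazol-2-yl group on the same chain carbon would bear on that.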